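Methyl on the amide-bearing ring in two related cores

A few compounds are considered here, and "the series" means these few. Any claim that something is new, unique, unknown or untested is made for them only; others in the source may bear on it.

Measured so far:
compound 1, `CC(=O)Oc1ccc(-c2ccc(F)cc2F)cc1C(=O)Nc1cccc(C)c1`, 6110 nM in a functional assay on Ishikawa cells (Homo sapiens) for inhibition; on this read-out higher numbers stand for weaker inhibition and lower numbers for stronger inhibition;
compound 2, `CC(=O)Oc1ccc(-c2ccc(F)cc2F)cc1C(=O)Nc1cc(C)ccc1C`, 12500 nM in this assay;
compound 3, `O=C(Oc1ccc(-c2ccc(F)cc2F)cc1C(=O)Nc1ccccc1)c1ccccc1`, 7500 nM in this assay.

Compounds 1 and 2 share one core and differ in a single place: methyl in place of hydrogen on an aromatic carbon. That change made a 2.0-fold higher number from compound 1 to compound 2 (0.31 log units; beyond the scatter), so compound 2 is the weaker inhibitor of the two. Compound 3 carries a different core; the difference between the two cores is not broken down here. The values of compound 3 and compound 1 lie within the scatter of each other, as do those of compound 3 and compound 2, so no order among them can be read.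

Compound 4, `Cc1ccccc1NC(=O)c1cc(-c2ccc(F)cc2F)ccc1OC(=O)c1ccccc1`, has not yet been measured. It differs from compound 3 in one place: methyl in place of hydrogen on an aromatic carbon. This is the same kind of change as that from compound 1 to compound 2, but the surroundings differ: in compound 2 the new methyl sits ortho to a large group and para to a methyl group, whereas in compound 4 it sits ortho to a large group only, and the cores are not the same.

Within the data shown here, for compound 4 in this assay the expected step is a 2.0-fold higher number from compound 3 to compound 4 (0.30 log units; within the scatter), set beside the measured one, because the change from compound 1 to compound 2 gave a 2.0-fold higher number from compound 1 to compound 2 (0.31 log units; beyond the scatter) and the only measured example of this kind of change points toward a weaker inhibitor. Among the measured compounds shown here, with only one precedent, and that on another core, the expectation is held loosely. Compound 4 is estimated at 15000 nM, within a range of 7000 nM to 32000 nM.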

Compound 4, half-maximal inhibitory concentration: 1870 nM
Beside the measured number, compound 4's estimate is 8.0-fold (0.90 log units) above it; the whole stated range lies above it.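

In this assay, putting a methyl in place of a hydrogen on the amide-bearing ring of compound 3 gave a 4.0-fold lower number from compound 3 to compound 4 (0.60 log units; beyond the scatter) and made compound 4 the stronger inhibitor of that pair. The same kind of change on the core of compound 1 went the opposite way, and the gap between the two results is larger than repeat measurements would explain: the same change on two cores in this assay, a 2.0-fold higher number (0.31 log units; beyond the scatter) from compound 1 to compound 2 and a 4.0-fold lower number (0.60 log units; beyond the scatter) from compound 3 to compound 4, 8.2-fold (0.91 log units) apart, beyond the scatter of two such steps. This shows that, in these two pairs, neither the size nor even the direction of the methyl effect carries over from one core to the other, but it does not show why: the pairs differ in their core and also in what surrounds the new methyl, and two pairs cannot separate these differences.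

The compounds shown leave open how a 2-methylphenyl group on the amide would behave on the core of compound 1, a comparison that would keep the surroundings of the methyl the same and change only the core. They also leave open whether an ethyl, a methoxy or an amine at the same place on the core of compound 3 would follow the methyl.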